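A few compounds are considered here, and "the series" means these few. Any claim that something is new, unique, unknown or untested is made for them only; others in the source may bear on it.

Measured in an assay for inhibition of inositol hexakisphosphate kinase 2 (Homo sapiens), read by colorimetric assay, coupled enzyme assay and malachite green, with a stated time of 120 min, in the presence of a further agent that is not named here; a lower number here means a stronger inhibitor, a higher number a weaker inhibitor:
compound 1 `COC(=O)/C=C/c1ccc2noc(-c3ccccc3)c2c1` gives 1580 nM.
compound 2 `O=C(O)/C=C/c1ccc2noc(-c3ccc(Oc4ccccc4)cc3)c2c1` gives 94 nM.
compound 3 `O=C(O)c1ccc2noc(-c3ccc(Oc4ncc(Cl)cc4Cl)cc3)c2c1` gives 650 nM.

Compound 3 holds the second highest of the three numbers in this assay; the number of compound 1 stands above it by a margin beyond the scatter, and the number of compound 2 lies below it, further away and also beyond the scatter. Among the compounds with values here, no two measured compounds differ in one place only, so no single change has a measured size in this set. Compound 4 `O=C(O)c1ccc2noc(-c3ccc(NC(=O)c4ccccc4)cc3)c2c1` carries benzamido in place of (3,5-dichloropyridin-2-yl)oxy on an aromatic carbon. Within the data shown here, with no comparable measured step to lean on, the expected step of a 1.1-fold higher number from compound 3 to compound 4 (0.03 log units; within the scatter) is set at none beyond the scatter, in neither direction. Compound 4 is accordingly estimated at 700 nM, within a range from 200 nM to 2500 nM.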

Compound 4, half-maximal inhibitory concentration: 580 nM
Beside the measured number, compound 4's estimate is 1.2-fold (0.08 log units) above it; measured number inside the range.
By their numbers in this assay, from the lowest: compound 2; then compounds 4 and 3 (each within the scatter of the next); then compound 1.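

At the aromatic carbon para to a large group, benzamido in place of (3,5-dichloropyridin-2-yl)oxy gives a 1.1-fold lower number from compound 3 to compound 4 (0.05 log units; within the scatter) in this assay. This position therefore accepts an exchange of the whole group, with both chlorines and the ring nitrogen gone and a hydrogen-bond donor brought in, and the two numbers remain indistinguishable. No measurement on hand accounts for this equivalence.

Open, as far as these compounds go, is whether the amide hydrogen of compound 4 matters, which a methyl group on the amide nitrogen would test. Also open, from the compounds shown here alone, is whether a sulfonamide link would serve in place of the amide.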